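Aryl group on the ring nitrogen: outlook for compound 4

The source may report more compounds than this note shows. Statements on the series, on what has been measured and on what is new or still open speak of the compounds shown alone.

Measured so far in a functional assay on HepG2 cells (Homo sapiens) for inhibition, read by MTT assay, with a stated time of 72 h; a higher number here means a weaker inhibitor, a lower number a stronger inhibitor:
compound 1 `Cc1cccc(-n2cc(COc3cccc(NC(=O)Nc4ccc(Cl)c(C(F)(F)F)c4)c3)nn2)c1`: 7270 nM
compound 2 `Cc1ccc(-n2cc(COc3cccc(NC(=O)Nc4ccc(Cl)c(C(F)(F)F)c4)c3)nn2)cc1`: 5430 nM
compound 3 `CCc1ccc(-n2cc(COc3cccc(NC(=O)Nc4ccc(Cl)c(C(F)(F)F)c4)c3)nn2)cc1`: 1950 nM

Compound 3 stands lowest of the three numbers; its nearest neighbour is compound 2, then compound 1, both beyond the scatter. Compound 4 `O=C(Nc1cccc(OCc2cn(-c3cccc(F)c3)nn2)c1)Nc1ccc(Cl)c(C(F)(F)F)c1` carries 3-fluorophenyl in place of 4-ethylphenyl on an aromatic nitrogen. For the measured compounds named here, the steps that bear on this are a 3.7-fold lower number from compound 1 to compound 3 (0.57 log units; beyond the scatter) and a 2.8-fold lower number from compound 2 to compound 3 (0.44 log units; beyond the scatter), both modest and both favouring the 4-ethylphenyl; a 1.3-fold lower number from compound 1 to compound 2 (0.13 log units; within the scatter) is within the scatter, so the position of a methyl alone shows nothing. Going by the values given here, no measured step involves fluorine, and compound 4 changes both the group and its position at once. Compound 4 is therefore expected to give a higher number than compound 3, roughly reversing the step from compound 1, with a 3.1-fold higher number from compound 3 to compound 4 (0.49 log units; beyond the scatter) in this assay. The estimate for compound 4 is 6000 nM, range 2500 nM to 15000 nM.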

Compound 4, half-maximal inhibitory concentration: 2120 nM
Estimate against measurement, compound 4: 2.8-fold (0.45 log units) above, outside the stated range (below it).
By their numbers in this assay, from the lowest: compounds 3 and 4 (each within the scatter of the next); then compounds 2 and 1 (each within the scatter of the next).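

In this assay the 3-fluorophenyl on the aromatic nitrogen does as well as the 4-ethylphenyl, with a 1.1-fold higher number from compound 3 to compound 4 (0.04 log units; within the scatter), so a low number at this position does not require an ethyl chain. The same group also stands apart from both methylphenyl compounds, with a 2.6-fold lower number from compound 2 to compound 4 (0.41 log units; beyond the scatter) and a 3.4-fold lower number from compound 1 to compound 4 (0.54 log units; beyond the scatter), the latter being fluoro in place of methyl on an aromatic carbon. No measurement at hand gives a reason for these steps. 

Still open, from the compounds shown here alone, is how a propyl chain, an amine or a carboxylic acid on this phenyl ring would compare.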